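Isopentyl to butyl in a small series

The source may hold more compounds than are shown below. What is called first, only, known or untested is meant among the compounds shown, and "the series" means these compounds.

Compound 1 `CCCC1=C(OC)C(CCC)(CCC)C(=O)/C(=C(O)\C=C\c2ccccc2)C1=O` gives "not determined" (no result reported) in a functional assay on HepG2 cells (Homo sapiens) for antiproliferative activity, read by sulforhodamine B assay, with a stated time of 3 days (a higher number here means that more compound is needed for the effect, a lower number that less compound is needed), and so offers no comparison. For the measured compounds named here, compound 2 `CCCC1=C(OCCC(C)C)C(CCC)(CCC)C(=O)/C(=C(O)\C=C\c2ccccc2)C1=O` reads 15.5 uM in this assay and holds the only number, with nothing yet to rank it against. Compound 3 `CCCCOC1=C(CCC)C(=O)/C(=C(O)/C=C/c2ccccc2)C(=O)C1(CCC)CCC` keeps the shared core and differs from compound 2 at a single place: hydrogen in place of methyl on a saturated chain carbon bound to two saturated chain carbons with hydrogen in place of methyl on a saturated chain carbon bound to two saturated chain carbons, which also reads as isopentyl to butyl. Going by the values given here, no measured pair shows what such a change does, so the expectation rests only on its small size. Expected for this change in this assay is a 1.1-fold lower number from compound 2 to compound 3 (0.04 log units; within the scatter) with no move beyond the scatter anticipated. For compound 3 the estimated value is 14 uM within an expected range of 7 uM to 30 uM for this measurement.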

Compound 3, concentration for half-maximal effect: 8 uM
Estimate against measurement, compound 3: 1.8-fold (0.24 log units) above; measured number inside the range.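

Going from isopentyl to butyl, the first measured change at this place, gives a 1.9-fold lower number from compound 2 to compound 3 (0.29 log units; within the scatter) in this assay, so removing this methyl on a saturated chain carbon bound to two saturated chain carbons does not separate the two compounds, and they cannot be ranked against each other. This single pair therefore gives no sign that the branch matters for this read-out, though it cannot show the same for other changes on this chain. No supporting measurement is available that would explain this result.

Steps to compound 1 cannot be read, so the series gives no view of how chain length acts at this place. As far as these compounds go, whether a longer chain, or an amine or a carboxylic acid in place of the butyl group, would move the number beyond the scatter remains open.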